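The source may hold more compounds than are shown below. What is called first, only, known or untested is meant among the compounds shown, and "the series" means these compounds.

Compound 1 `CN1Cc2ccc(O)cc2[C@@H](OCc2ccccc2)C1` gives > 50000 nM in an ADME assay on Vero cells (Chlorocebus sabaeus) for cytotoxicity, read by sulforhodamine B assay, with a stated time of 72 h (a higher number here means a weaker inhibitor, a lower number a stronger inhibitor), which is a limit of the assay and not a number.
Compound 2 `CN1Cc2ccc(O)cc2[C@@H](OCc2ccc(-c3ccccc3)cc2)C1` gives > 50000 nM in this assay, again only a limit of the assay.

Within the data shown here, compound 1 therefore stands nowhere definite on the scale: its value is a limit, and the one other value shown is a limit as well, since (the limit of > 50000 nM in this assay, at which 2 of the 2 values shown sit). Among the measured compounds shown here, the only measured step, a step that the two limits leave unreadable from compound 1 to compound 2, changes the same benzyloxy end of the molecule as the step now followed, yet it cannot be read because both ends sit at the limit.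

Compound 3 `CN1Cc2ccc(O)cc2[C@@H](OCCC2CCCCC2)C1` differs from compound 1 by cyclohexylmethyl in place of phenyl on a saturated chain carbon bound to an oxygen on a saturated carbon. For the measured compounds named here, no measured step gives a readable size for a change of this kind, so nothing argues for a shift in this assay beyond the scatter in either direction; the replacement of phenyl by cyclohexylmethyl is simply untested here. Compound 3 is expected to remain at the limit as well, with an estimated 50000 nM and a range from 20000 nM to 100000 nM. The expected step from compound 1 to compound 3 is accordingly a number no higher from compound 1 to compound 3 (the limit leaves the size open).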

Compound 3, half-maximal inhibitory concentration: > 50000 nM
Compound 3 was reported as a limit (the forecaster's own chance of this, stated with the estimate: 80%); the middle value lies on the limit itself.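

Compound 3 gives > 50000 nM in this assay, which is a limit of the assay. The step from compound 1 to compound 3 cannot be read, since both compounds sit at a limit: the limit of > 50000 nM in this assay, at which 3 of the 3 values shown sit.

The compounds shown leave open whether phenyl and cyclohexylmethyl differ at all in this assay.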